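The compounds below may be only part of what the source reports. "The series", "measured", "known", "first", "only" and "open" are said of these compounds alone.

Of the compounds shown here, three built on one shared core have been tested in a functional assay on Bel-7402 cells (Homo sapiens) for cytotoxicity, read by MTT assay; on this read-out higher numbers stand for weaker inhibition and lower numbers for stronger inhibition. Compound 1 `Cc1ccccc1Nc1nc(C)c(C(=O)/C=C/c2ccc(Cl)cc2)s1` gives only a limit there, > 25000 nM, which is a boundary of the assay and not a number. Compound 2 `Cc1ccc(Nc2nc(C)c(C(=O)/C=C/c3ccc(Cl)cc3)s2)cc1` likewise gives a limit, > 25000 nM. Compound 3 `Cc1nc(Nc2ccc(Cl)cc2)sc1C(=O)/C=C/c1ccc(Cl)cc1` also stops at a limit, > 25000 nM. On the numbers shown, compound 3 therefore stands at the same boundary as the other two, and nothing separates them. The steps among them, a step that the two limits leave unreadable from compound 1 to compound 2, a step that the two limits leave unreadable from compound 1 to compound 3 and a step that the two limits leave unreadable from compound 2 to compound 3, cannot be read, because of the limit of > 25000 nM in this assay, at which 3 of the 3 values shown sit.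

Compound 4 `Cc1nc(Nc2cccc(Cl)c2)sc1C(=O)/C=C/c1ccc(Cl)cc1` has not yet been measured. It differs from compound 3 by 3-chlorophenyl in place of 4-chlorophenyl on a nitrogen on an aromatic ring. All three measured steps bear on this change in that each also alters the group on that nitrogen, yet every one of them was unreadable, so no size and no direction can be taken from them. The expectation is a step that the limit leaves unreadable from compound 3 to compound 4, which is to say another result sitting at the boundary rather than a readable change. Compound 4 is accordingly estimated at 40000 nM, within a range from 15000 nM to 120000 nM, and most likely reported only as a limit.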

Compound 4, half-maximal inhibitory concentration: > 25000 nM
Compound 4: no number, only a limit; the forecaster's own chance of this, stated with the estimate: 80%; the middle value lies beyond the limit too.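

Compound 4 gives only a limit in this assay, so no step from compound 1, compound 2 or compound 3 to compound 4 can be read, because all four compounds stop at the same boundary: the limit of > 25000 nM in this assay, at which 4 of the 4 values shown sit.

The compounds shown leave open how far each lies beyond that limit, and whether changing the group on the nitrogen alters cytotoxicity at all.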